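The compounds below may be only part of what the source reports. "The series", "measured", "known", "first", "only" and "open" are said of these compounds alone.

The measured compounds are compound 1 `CCCc1cnc(C(=O)/C=C/c2ccc(O)cc2)cn1`, compound 2 `CCCCc1cnc(C(=O)/C=C/c2ccc(O)cc2)cn1` and compound 3 `CC(C)Cc1cnc(C(=O)/C=C/c2ccccc2O)cn1`. In a functional assay on the whole organism for inhibition, with Chlorella vulgaris as the target, read by spectrophotometry, with a stated time of 4 h (a higher number here means a weaker inhibitor, a lower number a stronger inhibitor), compound 1 gives 514000 nM, compound 2 gives 265000 nM and compound 3 gives 63000 nM. Compound 4 `CCCc1cnc(C(=O)/C=C/c2ccccc2O)cn1` has not yet been measured.

Compound 4 arises from compound 3 by hydrogen in place of methyl on a saturated chain carbon bound to two saturated chain carbons. The same kind of change, (hydrogen in place of methyl on a saturated chain carbon, three bonds along the chain from an aromatic carbon), is measured between compound 2 and compound 1, where it made a step of a 1.9-fold higher number from compound 2 to compound 1 (0.29 log units; within the scatter). The two changes are not the same: in compound 3 the place is on a saturated chain carbon bound to two saturated chain carbons, whereas in compound 2 it is on a saturated chain carbon, three bonds along the chain from an aromatic carbon. The difference between the cores of compound 2 and compound 3 is not broken down here. Compound 3 stands lowest of the three in this assay. For compound 4 the expected step is a 1.7-fold higher number from compound 3 to compound 4 (0.24 log units; within the scatter). That expectation rests on the measured step of a 1.9-fold higher number from compound 2 to compound 1 (0.29 log units; within the scatter). Compound 4 is therefore estimated at 110000 nM, with a likely range from 50000 nM to 250000 nM.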

Compound 4, half-maximal inhibitory concentration: 100000 nM
The estimate for compound 4 lay 1.1-fold (0.04 log units) above the measured number, within the range that was stated.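

In this assay, hydrogen in place of methyl gives a step of a 1.6-fold higher number from compound 3 to compound 4 (0.20 log units; within the scatter). Set beside the earlier case, the change reads alike on the two cores: the same change on two cores in this assay, a 1.9-fold higher number (0.29 log units; within the scatter) from compound 2 to compound 1 and a 1.6-fold higher number (0.20 log units; within the scatter) from compound 3 to compound 4, 1.2-fold (0.09 log units) apart, within the scatter of two such steps Since each step lies within the scatter, this shows only that the change leaves no clear mark on either core, and it does not show that the change has a real effect or that it would carry to any further core.

All the chains shown are saturated carbon chains, so a longer chain, an amine or a carboxylic acid at that place remains open. As far as these compounds go, a methoxy group in place of the hydroxyl remains open as well.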